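A few compounds are considered here, and "the series" means these few. Any claim that something is new, unique, unknown or untested is made for them only; others in the source may bear on it.

Of the compounds shown here, three built on the shared core have been measured, and all of them sit at the weak end of the scale. Compound 1 `O=C(CN1CCN(c2ccccc2)CC1)N1CCN(c2nnc(-c3ccc(Cl)cc3)c(-c3ccc(Cl)cc3)n2)CC1` gives in an ADME assay on NIH3T3 cells (Mus musculus) for cytotoxicity, read by MTT assay, with a stated time of 24 h (on this read-out higher numbers stand for weaker inhibition and lower numbers for stronger inhibition), a value that is only a limit of the assay, > 850000 nM. Compound 2 `COc1ccccc1N1CCN(CC(=O)N2CCN(c3nnc(-c4ccc(Cl)cc4)c(-c4ccc(Cl)cc4)n3)CC2)CC1` gives 405000 nM in this assay. Compound 3 `O=C(CN1CCN(c2cccc(Cl)c2)CC1)N1CCN(c2nnc(-c3ccc(Cl)cc3)c(-c3ccc(Cl)cc3)n2)CC1` again reaches only a limit of the assay in this assay, > 803000 nM. Compound 3 therefore stands at a limit, and one further value among the three is a limit as well.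

Compound 4 `COc1ccc(N2CCN(CC(=O)N3CCN(c4nnc(-c5ccc(Cl)cc5)c(-c5ccc(Cl)cc5)n4)CC3)CC2)cc1` differs from compound 3 by 4-methoxyphenyl in place of 3-chlorophenyl on an amine nitrogen in a ring. Of the measured steps, an at least 2.0-fold lower number from compound 1 to compound 2 (0.32 log units; beyond the scatter) shows that a methoxy on an aromatic carbon of this ring went with a lower number, while an at least 1.9-fold higher number from compound 2 to compound 3 (0.29 log units; that floor lies within the scatter) and a step that the two limits leave unreadable from compound 1 to compound 3 cannot be read with confidence. A modest move toward a lower number, or no readable change, is therefore expected here; the expected step is an at least 1.6-fold lower number from compound 3 to compound 4 (0.20 log units; that floor lies within the scatter). Compound 4 is accordingly estimated to give 500000 nM in this assay, in a range from 250000 nM to 1000000 nM.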

Compound 4, half-maximal inhibitory concentration: > 809000 nM
Compound 4 was reported as a limit; the forecaster's own chance of this, stated with the estimate: 45%; middle value at least 1.6-fold (0.20 log units) from the limit.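

The change from 2-methoxyphenyl to 4-methoxyphenyl gives an at least 1.9-fold higher number from compound 2 to compound 4 (0.30 log units; that floor lies within the scatter) in this assay, so a methoxy on this ring does not go with a lower number in every case, although the floor of this step does not settle the matter. Compound 4 stands at a limit of the assay: the limit of > 809000 nM in this assay, at which 1 of the 4 values shown sits. The steps joining compound 4 to compound 1 and to compound 3 cannot be read.

Going by these compounds, it remains open whether compound 2 truly differs from the other three compounds in this assay, or whether all four lie close together at the weak end of the scale. On these data alone, it also remains open whether a hydroxyl, an amine or a carboxylic acid on this ring would give a number clear of these limits.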